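Chloro to hydrogen on the aryl: cytotoxicity outlook for compound 4

The source may hold more compounds than are shown below. What is called first, only, known or untested is meant among the compounds shown, and "the series" means these compounds.

Compound 1 `COc1ccc(-n2n[o+]c([O-])c2-c2nn3cc(-c4cc5ccccc5oc4=O)nc3s2)cc1` was tested in a functional assay on HT-29 cells (Homo sapiens) for cytotoxicity, read by sulforhodamine B assay; a higher number here means that more compound is tolerated, a lower number that less compound is tolerated. In this assay compound 1 gives > 70 ug/mL, which is a limit of the assay and not a number. Compound 2 `COc1ccc(-n2n[o+]c([O-])c2-c2nn3cc(-c4cc5cc(Cl)ccc5oc4=O)nc3s2)cc1` carries the chloro group on the fused ring; in this assay compound 2 gives > 70 ug/mL, again a limit. The change between them is hydrogen in place of chloro on an aromatic carbon, and the step that the two limits leave unreadable from compound 2 to compound 1 cannot be read because both values are limits.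

Compound 3 `O=c1oc2ccc(Br)cc2cc1-c1cn2nc(-c3c([O-])[o+]nn3-c3ccc(Cl)cc3)sc2n1` has a different core; how its core differs from that of compound 2 is not broken down here. In this assay compound 3 gives > 70 ug/mL, a limit. All three measured values sit at the limit of > 70 ug/mL in this assay, at which 3 of the 3 values shown sit.

Compound 4 `O=c1oc2ccc(Br)cc2cc1-c1cn2nc(-c3c([O-])[o+]nn3-c3ccccc3)sc2n1` is the not yet measured partner of compound 3. The change is hydrogen in place of chloro on an aromatic carbon. It is the same kind of change as that from compound 2 to compound 1, but the place differs: in compound 3 the chloro sits on a six-membered aromatic ring of carbon only, para to a large group, whereas in compound 2 it sits on a ring that is part of a fused system of two rings, meta and para to a fused ring.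

Among the compounds with values here, with every measured value a limit, the step from compound 3 to compound 4 is expected to be small, a step that the limit leaves unreadable from compound 3 to compound 4, since the only comparable step that the two limits leave unreadable from compound 2 to compound 1 shows no readable effect. Compound 4 is therefore estimated at 80 ug/mL, within 45 ug/mL to 150 ug/mL, most probably reported again only as a limit.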

Compound 4, concentration lethal to 50% of the cells: > 70 ug/mL
Compound 4 was reported as a limit; the forecaster's own chance of this, stated with the estimate: 80%; the middle value is on the limit's open side.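

In this assay compound 4, like compound 3, is reported only as a limit and not as a number, so no step can be read between the two for 4-chlorophenyl to phenyl: the limit of > 70 ug/mL in this assay, at which 4 of the 4 values shown sit.

The compounds shown leave open whether hydrogen in place of chloro on an aromatic carbon has any effect in this assay, in either of the two places where it occurs.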